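From naphthalen-2-yl to 4-isobutylphenyl: compound 4

The source may report more compounds than this note shows. Statements on the series, on what has been measured and on what is new or still open speak of the compounds shown alone.

Results in a functional assay on the whole organism (strain BALB/c) with Mus musculus as the target, with a stated time of 4 h; a lower number here means that less compound is needed, a higher number that more compound is needed for the effect:
- Compound 1 `CC1=C(CN2CC(C(=O)O)C2)CCc2cc(OCc3ccc4ccccc4c3)ccc21`: "not determined" (no result reported)
- Compound 2 `CC1=C(CN2CC(C(=O)O)C2)CCc2cc(OCC3CCc4ccccc4C3)ccc21`: "not determined" (no result reported)
- Compound 3 `CC1=C(CN2CC(C(=O)O)C2)CCc2cc(OCCC3CCc4ccccc43)ccc21`: > 1 mg/kg (a limit)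

Compound 1 has no single number to start from, as its entry in this assay reads "not determined" (no result reported). The only other result in the series is the limit for compound 3.

Compound 4 `CC1=C(CN2CC(C(=O)O)C2)CCc2cc(OCc3ccc(CC(C)C)cc3)ccc21` has not yet been measured. The structural change is 4-isobutylphenyl in place of naphthalen-2-yl on a saturated chain carbon bound to an oxygen on an aromatic ring: 4-isobutylphenyl replaces naphthalen-2-yl on a saturated chain carbon bound to an oxygen on an aromatic ring.

Without a number for compound 1, the step in this assay has no measured baseline, so no change beyond the scatter is expected by default. For compound 4 the half-maximal dose is estimated at 0.5 mg/kg, with an expected range of 0.1 mg/kg to 2.5 mg/kg.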

Compound 4, dose for half-maximal effect: 0.39 mg/kg
Compound 4: the middle estimate sits 1.3-fold (0.11 log units) above what was measured, within the range that was stated.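

Compound 4 gives the series its first single number in this assay, showing that 4-isobutylphenyl on a saturated chain carbon bound to an oxygen on an aromatic ring is compatible with a measurable half-maximal dose. Compound 3 has only a limit, > 1 mg/kg. Against that limit the change is an at least 2.5-fold lower number from compound 3 to compound 4 (0.40 log units; beyond the scatter), and its full size stays unknown.

With no number for compound 1, the exchange of naphthalen-2-yl for 4-isobutylphenyl cannot be sized. As far as these compounds go, how a trifluoromethyl or a longer chain in place of the isobutyl would fare also remains open.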